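From ethyl to acetyl on an amide-type nitrogen

A few compounds are considered here, and "the series" means these few. Any claim that something is new, unique, unknown or untested is made for them only; others in the source may bear on it.

In an ADME assay on MDBK cells (Bos taurus) for cytotoxicity, read by MTT assay, with a stated time of 96 h (a lower number here means that less compound is tolerated, a higher number that more compound is tolerated), compound 3 `CCNC(=S)Nc1cccc(C(F)(F)F)c1` gives > 100000 nM as a limit and not a number. Going by the values given here, compound 2 `CCCCc1ccc(NC(=S)Nc2cccc(C(F)(F)F)c2)c(C)c1` gives 10000 nM and is the only measured compound with an actual number. Compound 1 `O=C(NC(=S)Nc1cccc(C(F)(F)F)c1)c1ccccc1` also carries a carbonyl on an amide-type nitrogen and gives > 100000 nM as a limit too. Compound 4 `CC(=O)NC(=S)Nc1cccc(C(F)(F)F)c1` has acetyl in place of ethyl on an amide-type nitrogen. With compound 1 as the closest guide, the step of a number no higher from compound 3 to compound 4 (the limit leaves the size open) is expected to stay within the usual scatter, with no direction foreseen. For compound 4 the estimate is 100000 nM with an expected range from 40000 nM to 200000 nM and the reading may well be only a limit again.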

Compound 4, half-maximal cytotoxic concentration: > 100000 nM
Compound 4 ended at the assay's limit; the forecaster's own chance of this, stated with the estimate: 70%; the middle value lies on the limit itself.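

Compound 1, compound 3 and compound 4 all end at a limit, so the steps from compound 3 and from compound 1 to compound 4 cannot be read: the limit of > 100000 nM in this assay, at which 3 of the 4 values shown sit.

As far as these compounds go, whether acetyl and ethyl on the amide-type nitrogen differ at all stays open.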